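This account rests on a few compounds, and the source may have more. Where it says the series, first, only, none or still open, it means among the compounds named here.

Measured so far:
Compound 1 `C#CCn1cc(C(=O)NCCCOC(=O)[C@H]2CCCN2C(=O)OC(C)(C)C)c(=O)c2ccc(Cl)nc21` gives > 10000 nM.
Compound 2 `C#CCn1cc(C(=O)NCCCOC(=O)[C@H]2CCCN2C(=O)OC(C)(C)C)c(=O)c2ccc(C)nc21` gives > 10000 nM.

Both compounds share the core of compound 1 and were tested in a functional assay on K562 cells (Homo sapiens) for cytotoxicity, read by MTT assay, with a stated time of 72 h; a higher number here means a weaker inhibitor, a lower number a stronger inhibitor. For compound 1 the value > 10000 nM is a limit of the assay, not a number. For compound 2 the value > 10000 nM is likewise a limit. Within the data shown here, the one measured step, a step that the two limits leave unreadable from compound 1 to compound 2, therefore cannot be read in size: both of its ends sit at the limit of > 10000 nM in this assay, at which 2 of the 2 values shown sit.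

The compound still to be measured is compound 3 `C#CCn1cc(C(=O)N[C@@H](C)CCOC(=O)[C@H]2CCCN2C(=O)OC(C)(C)C)c(=O)c2ccc(Cl)nc21`. It differs from compound 1 by methyl in place of hydrogen on a saturated chain carbon bound to an amide-type nitrogen and a saturated chain carbon. Among the measured compounds shown here, no measured step touches this position; the only measured step concerns a different place and is itself unreadable, so it gives no guide to direction or size. With both measured compounds at the limit, the plain expectation is that compound 3 again shows no measurable inhibition.

Compound 3 is therefore estimated at 20000 nM, with a range from 5000 nM to 80000 nM, an expected step that the limit leaves unreadable from compound 1 to compound 3, most probably reported once more only as a limit.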

Compound 3, half-maximal inhibitory concentration: > 10000 nM
Compound 3 was reported as a limit; the forecaster's own chance of this, stated with the estimate: 80%; the middle value is on the limit's open side.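

In this assay, compound 1 and compound 3 are both reported only as limits, not numbers, so the step between them cannot be read in size: the limit of > 10000 nM in this assay, at which 3 of the 3 values shown sit.

The compounds shown leave open whether methyl in place of chloro, or methyl in place of hydrogen, changes the result in this assay at all.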